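Changing the 4-methylpiperazin-1-yl amide of compound 1

A few compounds are considered here, and "the series" means these few. Any claim that something is new, unique, unknown or untested is made for them only; others in the source may bear on it.

Measured so far in a functional assay on MV4-11 cells (Homo sapiens) for inhibition, read by luminescence, with a stated time of 3 days; on this read-out lower numbers stand for stronger inhibition of growth and higher numbers for weaker inhibition of growth:
compound 1 `CC(C)C1=C(C(=O)N2[C@H](C)CC[C@H]2C(=O)N2CCN(C)CC2)SC2=N[C@@](C)(c3ccc(Cl)cc3)[C@@H](c3ccc(Cl)cc3)N21`: 190 nM
compound 2 `CC[C@@H]1CC[C@@H](C(=O)N2CCN(C)CC2)N1C(=O)C1=C(C(C)C)N2C(=N[C@@](C)(c3ccc(Cl)cc3)[C@H]2c2ccc(Cl)cc2)S1`: 83 nM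
compound 3 `CC[C@@H]1CC[C@@H](C(=O)N2CCOCC2)N1C(=O)C1=C(C(C)C)N2C(=N[C@@](C)(c3ccc(Cl)cc3)[C@H]2c2ccc(Cl)cc2)S1`: 94 nM

Compound 1 gives the highest number of the three in this assay; compound 2 and compound 3 both sit lower, each beyond the scatter. The two measured steps differ in kind: a 2.3-fold lower number from compound 1 to compound 2 (0.36 log units; beyond the scatter), whereas a 1.1-fold higher number from compound 2 to compound 3 (0.05 log units; within the scatter).

Compound 4 `CC(=O)N1CCN(C(=O)[C@@H]2CC[C@@H](C)N2C(=O)C2=C(C(C)C)N3C(=N[C@@](C)(c4ccc(Cl)cc4)[C@H]3c3ccc(Cl)cc3)S2)C[C@@H]1C` is compound 1 with a group of 10 heavy atoms (7 carbon, 2 nitrogen, 1 oxygen; one six-membered non-aromatic ring with 2 hetero atoms) in place of a group of 7 heavy atoms (5 carbon, 2 nitrogen; one six-membered non-aromatic ring with 2 hetero atoms), on a carbonyl carbon. Among the measured compounds shown here, the one measured step that bears on this change is the amide swap, which left the number unchanged within the scatter between compound 2 and compound 3; the methyl step does not touch the amide and is not carried over. Nothing measured speaks to the acetyl or the ring methyl that enter. The expectation for compound 4 in this assay is therefore a number close to that of compound 1, a 1.1-fold lower number from compound 1 to compound 4 (0.05 log units; within the scatter), with no step beyond the scatter expected. The estimate for compound 4 is 170 nM, within 80 nM to 360 nM.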

Compound 4, concentration for 50% growth inhibition: 400 nM
For compound 4 the middle estimate is 2.4-fold (0.37 log units) below the measured one, and the stated range ends below it.
By their numbers in this assay, from the lowest: compounds 2 and 3 (each within the scatter of the next); then compound 1; then compound 4.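

In this assay, the amide on the carbonyl carbon proves able to move the number: a 2.1-fold higher number from compound 1 to compound 4 (0.32 log units; beyond the scatter), whereas the morpholin-4-yl swap gave a 1.1-fold higher number from compound 2 to compound 3 (0.05 log units; within the scatter). The indifference seen in that swap therefore does not extend to every replacement of 4-methylpiperazin-1-yl at this place, and the step beyond the scatter appears with the counts of hydrogen-bond donors, hydrogen-bond acceptors and net charge unchanged between the leaving and entering groups. No measurement at hand accounts for this step.

As far as these compounds go, the acetyl and the ring methyl enter together, so the share of each in the step remains open, as does the stereocentre that enters with them. Also open, from the compounds shown here alone, is how a plain piperazin-1-yl or an open-chain dimethylamino group would read on the same carbonyl carbon.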